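The source may report more compounds than this note shows. Statements on the series, on what has been measured and on what is new or still open speak of the compounds shown alone.

The measured compounds are:
compound 1 `O=C(/C=C/c1cccs1)c1cccc(NC(=O)c2cc(-c3ccncc3)n[nH]2)c1` with 27600 nM
compound 2 `COc1ccc(/C=C/C(=O)c2cccc(NC(=O)c3cc(-c4ccncc4)n[nH]3)c2)cc1` with 38400 nM
compound 3 `O=C(/C=C/c1ccccc1Cl)c1cccc(NC(=O)c2cc(-c3ccncc3)n[nH]2)c1` with 27700 nM

All three share a core and differ only in the aryl group on the double-bonded chain carbon bound to a double-bonded chain carbon. In a functional assay, read by spectrophotometry, tested at 100 uM (on this read-out lower numbers stand for stronger inhibition and higher numbers for weaker inhibition), compound 1 shows the lowest number of the three, but this tells little: the steps from it are a 1.0-fold higher number from compound 1 to compound 3 (0.00 log units; within the scatter) and a 1.4-fold higher number from compound 1 to compound 2 (0.14 log units; within the scatter), both within the scatter, and a 1.4-fold lower number from compound 2 to compound 3 (0.14 log units; within the scatter) is likewise within the scatter. The three aryl groups tried so far, thiophen-2-yl, 4-methoxyphenyl and 2-chlorophenyl, thus give numbers that cannot be told apart in this assay.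

Compound 4 `CC(C)c1ccc(/C=C/C(=O)c2cccc(NC(=O)c3cc(-c4ccncc4)n[nH]3)c2)cc1` carries the same core and differs from compound 1 by 4-isopropylphenyl in place of thiophen-2-yl on a double-bonded chain carbon bound to a double-bonded chain carbon. Within the data shown here, the steps that bear on this change are the three above, all of which exchange one aryl group for another at this same place, and none of them moved the number beyond the scatter. A fourth aryl group at this position is therefore expected to leave this assay essentially unchanged, and the expected step is a 1.1-fold higher number from compound 1 to compound 4 (0.04 log units; within the scatter). The estimate for compound 4 in this assay is 30000 nM, with a range from 15000 nM to 60000 nM.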

Compound 4, half-maximal inhibitory concentration: 52300 nM
For compound 4 the middle estimate is 1.7-fold (0.24 log units) below the measured one, and the stated range covers the measured number.
By their numbers in this assay, from the lowest: compounds 1, 3, 2 and 4 (each within the scatter of the next).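

In this assay the exchange of thiophen-2-yl for 4-isopropylphenyl, which puts 9 heavy atoms in place of 5 and a six-membered aromatic ring of carbon only in place of a five-membered aromatic ring with 1 hetero atom, gives a small step (a 1.9-fold higher number from compound 1 to compound 4 (0.28 log units; within the scatter)), and the same group in place of 2-chlorophenyl gives another (a 1.9-fold higher number from compound 3 to compound 4 (0.28 log units; within the scatter)). Both steps stay within the scatter, so the range of aryl groups at this place that cannot be told apart now extends to one carrying an isopropyl group. Among these compounds, the change of isopropyl for methoxy on an aromatic carbon, the only step here that leaves the ring itself in place and exchanges just its substituent, also stays within the scatter (a 1.4-fold higher number from compound 2 to compound 4 (0.13 log units; within the scatter)).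

No independent data bear on why these numbers lie where they do. On these data alone, it remains open whether an amine, a carboxylic acid or a cyclohexyl group at this place would give a number beyond the scatter of these four compounds, and whether any group here would bring the number clearly lower.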